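This account rests on a few compounds, and the source may have more. Where it says the series, first, only, none or still open, it means among the compounds named here.

Working notes on the series. Two compounds carry numbers in an assay on cells for agonist activity at ecdysone receptor (Bombyx mori), read by a luciferase reporter, with a stated time of 24 h; a higher number here means that more compound is needed for the effect, a lower number that less compound is needed. Compound 1 `CC(C)(C)N(NC(=O)c1ccccc1)C(=O)c1ccc(Cl)cc1Cl` gives 117 nM in this assay. Compound 2 `Cc1ccccc1C(=O)NN(C(=O)c1ccccc1Cl)C(C)(C)C` gives 72.4 nM in this assay, the lowest of the two numbers, though the gap to compound 1 lies within the scatter. Compound 3 `CC(C)(C)N(NC(=O)c1ccc(I)cc1)C(=O)c1ccccc1Cl` is not yet measured in this assay. It differs from compound 2 by one change: 4-iodophenyl in place of 2-methylphenyl on a carbonyl carbon. Within the data shown here, no single-point step between measured compounds exists to anchor the size of this change. A step of modest size toward a lower number is expected here, a 1.4-fold lower number from compound 2 to compound 3 (0.16 log units; within the scatter), and compound 3 is estimated to give 50 nM in this assay, between 15 nM and 200 nM.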

Compound 3, half-maximal effective concentration: 7.59 nM
Compound 3: middle estimate off by 6.6-fold (0.82 log units), on the high side, and the stated range ends above it.
By their numbers in this assay, from the lowest: compound 3; then compounds 2 and 1 (each within the scatter of the next).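

In this assay, the aryl group on a carbonyl carbon whose other neighbour is an amide-type nitrogen proves a sensitive place: 4-iodophenyl in place of 2-methylphenyl gives a 9.5-fold lower number from compound 2 to compound 3 (0.98 log units; beyond the scatter). The heavy-atom count and the donor and acceptor counts of the group stay the same, so these counts do not track the step. No measurement shown accounts for the size of this step.

Among these compounds, the single step does not separate the loss of the methyl group from the gain of the iodine. From the compounds shown here alone, whether 4-bromophenyl or 4-methoxyphenyl at this place would give a similar number remains open.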